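Trifluoromethyl in place of methylsulfanyl: working notes

The compounds below may be only part of what the source reports. "The series", "measured", "known", "first", "only" and "open" are said of these compounds alone.

Measured so far in a physicochemical assay for solubility, at pH 7.4; on this read-out lower numbers stand for lower solubility and higher numbers for higher solubility
- compound 1 `Cc1cc(NC(=O)Nc2ccccc2OC(F)(F)F)c2ccccc2n1` gives 4600 nM
- compound 2 `CSc1ccccc1NC(=O)Nc1cc(C)nc2ccccc12` gives 21000 nM
- compound 3 `COC(=O)c1cccc(NC(=O)Nc2cc(C)nc3ccccc23)c1` gives 600 nM

In this assay compound 2, at 21000 nM, holds the highest of the three numbers. Compound 1 stands nearest at 4600 nM and compound 3 furthest at 600 nM.

The next change leads to compound 4 `Cc1cc(NC(=O)Nc2ccccc2C(F)(F)F)c2ccccc2n1`, with trifluoromethyl in place of methylsulfanyl on an aromatic carbon, ortho to a large group (trifluoromethyl in place of methylsulfanyl on an aromatic carbon). Among the compounds with values here, no measured step has trifluoromethyl entering. Within the data shown here, the only step bearing on this place is a 4.6-fold higher number from compound 1 to compound 2 (0.66 log units; beyond the scatter), modest and beyond the scatter, with methylsulfanyl in place of trifluoromethoxy on an aromatic carbon. Among the measured compounds shown here, compound 3 offers no step on this change. Read backward, that single step suggests that leaving methylsulfanyl for trifluoromethyl may give a modest drop of similar size in this assay, though one step is thin support. The estimate for this change is a 3.5-fold lower number from compound 2 to compound 4 (0.54 log units; beyond the scatter), an expected move to a lower number. For compound 4 the expected value is 6000 nM, with an estimated range of 2000 nM to 18000 nM.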

Compound 4, solubility: 3800 nM
For compound 4 the middle estimate is 1.6-fold (0.20 log units) above the measured one; the measured number falls inside the stated range.
By their numbers in this assay, from the lowest: compound 3; then compounds 4 and 1 (each within the scatter of the next); then compound 2.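

In this assay, trifluoromethyl in place of methylsulfanyl gives a 5.5-fold lower number from compound 2 to compound 4 (0.74 log units; beyond the scatter), so the higher number of compound 2 is no longer set against trifluoromethoxy alone. Trifluoromethyl in place of trifluoromethoxy gives a 1.2-fold lower number from compound 1 to compound 4 (0.08 log units; within the scatter), so these two groups cannot be told apart at this position on this read-out, and among the three groups compared here only methylsulfanyl stands apart. No measurement at hand accounts for that difference.

From the compounds shown here alone, whether the higher number is particular to methylsulfanyl or would also appear with another group at this position, such as an amine, a methoxy group or a longer sulfur-bearing chain, remains open. Compound 3 differs from these compounds in more than one place and gives no reading on this position.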